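Replacing the Sulfonyl Aryl Group: Compound 3 to Compound 4

The source may hold more compounds than are shown below. What is called first, only, known or untested is meant among the compounds shown, and "the series" means these compounds.

Three measured compounds share one core. Compound 1 `COc1ccc(S(=O)(=O)c2ccccc2)c(Cc2c3c(n(CC(=O)O)c2C)CCNC3=O)c1` gives 3.6 nM in a functional assay on CHO.K1 cells for antagonist activity at prostaglandin D2 receptor 2 (Homo sapiens), read by GTPgammaS binding, with a stated time of 1 h; on this read-out lower numbers stand for stronger inhibition and higher numbers for weaker inhibition. Among the measured compounds shown here, compound 2 `Cc1c(Cc2cc(Br)ccc2S(=O)(=O)c2ccccc2)c2c(n1CC(=O)O)CCNC2=O` gives 3.9 nM in this assay, and the only measured single-point step, a 1.1-fold higher number from compound 1 to compound 2 (0.03 log units; within the scatter), changes a substituent on the aromatic ring that carries the methylene, not the aryl on the sulfonyl sulfur. Compound 3 `Cc1c(Cc2ccccc2S(=O)(=O)c2ccccc2F)c2c(n1CC(=O)O)CCNC2=O` gives 3.6 nM in this assay; that number matches compound 1 at the digits shown, and compound 2 lies within the scatter of both, so no order among the three can be read from these values.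

Compound 4 `COc1ccc(S(=O)(=O)c2ccccc2Cc2c3c(n(CC(=O)O)c2C)CCNC3=O)cc1` is not yet measured. It differs from compound 3 by 4-methoxyphenyl in place of 2-fluorophenyl on a sulfonyl sulfur. For the measured compounds named here, no measured pair in this set changes the aryl on the sulfonyl sulfur alone; compound 1 and compound 3 differ there but also elsewhere, and their values show no gap at the digits printed. Going by the values given here, the one step that exists, on the other ring, lies within the scatter. On that basis compound 4 is expected to give a number close to compound 3, with a step of a 1.1-fold higher number from compound 3 to compound 4 (0.05 log units; within the scatter) that stays within the scatter. The estimate for compound 4 in this assay is 4 nM, in a range from 1.5 nM to 12 nM.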

Compound 4, half-maximal inhibitory concentration: 3.9 nM
Compound 4: middle estimate off by 1.0-fold (0.01 log units), on the high side, and the stated range covers the measured number.
By their numbers in this assay, from the lowest: compounds 1, 3, 2 and 4 (each within the scatter of the next).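

In this assay, among the compounds shown here, exchanging 2-fluorophenyl for 4-methoxyphenyl on a sulfonyl sulfur gives a 1.1-fold higher number from compound 3 to compound 4 (0.03 log units; within the scatter), the first reading of a change to this aryl group alone, since compound 1 and compound 3 also differ elsewhere. The entering group has 8 heavy atoms against 7 and 1 hydrogen-bond acceptor against 0, yet the two aryl groups cannot be told apart in this read-out, and the step on the other ring, a 1.1-fold higher number from compound 1 to compound 2 (0.03 log units; within the scatter), is likewise within the scatter. Nothing available bears on why these two aryl groups read alike.

On these data alone, both groups compared here are substituted phenyl rings, so it remains open whether the result would hold with a methyl or cyclopropyl group on the sulfonyl sulfur, or with a phenyl ring carrying an amine or a carboxylic acid. Since every step shown lies within the scatter, the compounds also leave open which change at this position, if any, would move the number clearly.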